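Working notes on two measured amides and one gap

The source may hold more compounds than are shown below. What is called first, only, known or untested is meant among the compounds shown, and "the series" means these compounds.

Measured so far:
- compound 1, `CCc1ccc2nc(C(=O)Nc3c(F)cc(-c4cccc(F)c4)cc3F)c(C)c(O)c2c1`: 12.3%
- compound 2, `Cc1ccc2nc(C(=O)Nc3c(F)cc(-c4cccc(F)c4)cc3F)c(C)c(C(=O)O)c2c1`: 3.65%

In a functional assay on A-375 cells (Homo sapiens) for antiproliferative activity, read by MTT assay, with a stated time of 24 h, tested at 1.23 ug/mL (on this read-out higher numbers stand for a stronger effect at the one concentration tested and lower numbers for a weaker effect), compound 1 gives 12.3% and compound 2 gives 3.65%. On these two numbers compound 2 cannot be set apart from compound 1: the gap between them is within the usual scatter of repeated measurements, so nothing about order is known between them. Compound 1 and compound 2 also differ in more than one place, so no single step can be read from the pair.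

Compound 3, `CCc1ccc2nc(C(=O)Nc3c(F)cc(-c4cccc(F)c4)cc3F)c(C)c(C(=O)O)c2c1`, has not yet been measured. It differs from compound 2 by methyl in place of hydrogen on a saturated chain carbon bound to an aromatic carbon; the same difference, cut one bond further out, reads methyl to ethyl. Among the compounds with values here, no measured pair shows a change of this kind, so the size of its step rests on no data. The expectation is a step from compound 2 to compound 3 of a number 2.4 percentage points higher from compound 2 to compound 3 (within the scatter), that is, none beyond the scatter. Compound 3 is estimated at 6%, with a range of -5% to 20% in this assay.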

Compound 3, a percentage reported as inhibition, at one concentration (the size of the read-out at that concentration, not a potency): 17.7%
The estimate for compound 3 lay 11.7 percentage points below the measured number; the measured number falls inside the stated range.
By their numbers in this assay, from the lowest: compounds 2, 1 and 3 (each within the scatter of the next, the first and the last beyond it).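

In this assay, within the data shown here, methyl in place of hydrogen on a saturated chain carbon bound to an aromatic carbon, which reads methyl to ethyl one bond further out, gives a number 14.1 percentage points higher from compound 2 to compound 3 (beyond the scatter) and so supplies the first single-place step beyond the scatter. That step shows that this position can register a one-carbon change on a core carrying carboxy, though it rests on a single pair of compounds at one concentration. With ethyl held in place, carboxy in place of hydroxy on an aromatic carbon gives a number 5.4 percentage points higher from compound 1 to compound 3 (within the scatter) and leaves these two groups unresolved on this read-out, while nothing at hand accounts for either step.

The compounds shown leave open whether a longer chain such as propyl, or a branched one such as isopropyl, would carry the step from methyl to ethyl further or reverse it. They also leave open whether methyl to ethyl gives a step of similar size with hydroxy on the aromatic carbon, and whether an amine there would stand apart from carboxy and hydroxy.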